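A few compounds are considered here, and "the series" means these few. Any claim that something is new, unique, unknown or untested is made for them only; others in the source may bear on it.

Working notes on the series. Within the data shown here, in a physicochemical assay for permeability, using PAMPA (on this read-out higher numbers stand for higher permeability and lower numbers for lower permeability), compound 1 `Cc1oc(-c2c(F)cccc2F)nc1CN1CCC(C(=O)NCCCN2C[C@H](C)C[C@H](C)C2)CC1` gives 82.4 10^-6 cm/s, the lowest of the three numbers measured so far. Compound 2 `CC[C@@H]1C[C@H](CC)CN(CCCNC(=O)C2CCN(Cc3nc(-c4c(F)cccc4F)oc3C)CC2)C1` gives 130 10^-6 cm/s in this assay, and the step of a 1.6-fold higher number from compound 1 to compound 2 (0.20 log units; within the scatter) lies within the scatter. Among the measured compounds shown here, compound 3 `CCCN(CCC)CCNC(=O)C1CCN(Cc2nc(-c3ccccc3C)oc2C)CC1` gives 913 10^-6 cm/s in this assay; it differs from compound 1 at more than one place, so no single step is drawn from that pair. Compound 4 `COc1cccc(C)c1-c1nc(CN2CCC(C(=O)NCCCN3C[C@H](C)C[C@H](C)C3)CC2)c(C)o1` differs from compound 1 by 2-methoxy-6-methylphenyl in place of 2,6-difluorophenyl on an aromatic carbon. For the measured compounds named here, no measured step touches this position; the only single-place step known, a 1.6-fold higher number from compound 1 to compound 2 (0.20 log units; within the scatter), concerns the saturated chain end and is within the scatter. For compound 4 no step beyond the scatter is therefore expected, a 1.2-fold higher number from compound 1 to compound 4 (0.06 log units; within the scatter). Compound 4 is estimated at 95 10^-6 cm/s, with a range from 45 10^-6 cm/s to 200 10^-6 cm/s.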

Compound 4, apparent permeability: 198 10^-6 cm/s
Estimate against measurement, compound 4: 2.1-fold (0.32 log units) below; the measured number falls inside the stated range.
By their numbers in this assay, from the lowest: compounds 1, 2 and 4 (each within the scatter of the next, the first and the last beyond it); then compound 3.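

On the aromatic carbon of the five-membered ring, the swap of 2,6-difluorophenyl for 2-methoxy-6-methylphenyl gives in this assay a 2.4-fold higher number from compound 1 to compound 4 (0.38 log units; beyond the scatter) and is modest in size. Among these compounds, this is the first single-place step beyond the scatter, and the only earlier one, at the saturated chain end, lay within it. No measured evidence bears on the cause of this step. The compounds shown leave open whether the methoxy or the methyl group carries the step, and how 2,6-dimethylphenyl or unsubstituted phenyl would read at this place in this assay.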